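Replacing Methylsulfanyl on the Shared Core: Compound 3 Expected

A few compounds are considered here, and "the series" means these few. Any claim that something is new, unique, unknown or untested is made for them only; others in the source may bear on it.

Measured compounds:
Compound 1, `CCOC(=O)c1cnc(SC)nc1NN1C(=O)C=C(C)C1=O`: 200 nM
Compound 2, `CCOC(=O)c1cnc(-c2cccc([N+](=O)[O-])c2)nc1NN1C(=O)C=C(C)C1=O`: 7000 nM

In a functional assay on Jurkat cells for inhibition of nuclear factor NF-kappa-B complex (Homo sapiens) (a higher number here means a weaker inhibitor, a lower number a stronger inhibitor), compound 1 gives 200 nM, the lowest of the two numbers, while compound 2 gives 7000 nM. For the measured compounds named here, the one measured step, a 35-fold higher number from compound 1 to compound 2 (1.54 log units; beyond the scatter), was large. Compound 3, `CCOC(=O)c1cnc(CC2=CCCCC2)nc1NN1C(=O)C=C(C)C1=O`, carries a different change at the same place: (cyclohex-1-en-1-yl)methyl in place of methylsulfanyl on an aromatic carbon. Going by the values given here, only that step bears on this change, and it points toward weaker inhibition whenever methylsulfanyl is replaced by a larger group. A weakening step is therefore expected for compound 3, likely smaller, as a 10-fold higher number from compound 1 to compound 3 (1.00 log units; beyond the scatter). Compound 3 is estimated at 2000 nM, within 400 nM to 10000 nM.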

Compound 3, half-maximal inhibitory concentration: 2000 nM
For compound 3 middle estimate and measured number coincide at the digits printed; measured number inside the range.
By their numbers in this assay, from the lowest: compound 1; then compound 3; then compound 2.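

Replacing methylsulfanyl with (cyclohex-1-en-1-yl)methyl also weakens inhibition (a 10-fold higher number from compound 1 to compound 3 (1.00 log units; beyond the scatter)), so a second, quite different group at this position fails to match compound 1. The size of the loss depends on the entering group: (cyclohex-1-en-1-yl)methyl in place of 3-nitrophenyl gives stronger inhibition (a 3.5-fold lower number from compound 2 to compound 3 (0.54 log units; beyond the scatter)). Nothing available explains the difference between these groups. On these data alone, whether an amine or a methoxy group here would keep the inhibition of compound 1 stays open. So does whether this order of groups would hold with a change elsewhere on the shared core.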